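The compounds below may be only part of what the source reports. "The series", "measured", "known", "first", "only" and "open" are said of these compounds alone.

Compound 1 `Oc1ccc(-c2nc3cc(C(F)(F)F)ccc3[nH]2)cc1`: 17000 nM
Compound 2 `COc1ccc(-c2nc3cc(C(F)(F)F)ccc3[nH]2)cc1`: 2000 nM
Compound 3 `CCN(CC)CC(=O)Nc1ccc(-c2nc3cc(C(F)(F)F)ccc3[nH]2)cc1`: 8000 nM

In an ADME assay on MT4 cells (Homo sapiens) for cytotoxicity, read by MTT assay, with a stated time of 96 h (on this read-out lower numbers stand for higher toxicity in this test and higher numbers for lower toxicity in this test), compound 3 gives 8000 nM, the second highest of the three numbers. Compound 1 stands nearest to it, with a 2.1-fold lower number from compound 1 to compound 3 (0.33 log units; beyond the scatter), and compound 2 furthest, with a 4.0-fold higher number from compound 2 to compound 3 (0.60 log units; beyond the scatter). The third measured step, an 8.5-fold lower number from compound 1 to compound 2 (0.93 log units; beyond the scatter), likewise changes only the group on the aromatic carbon.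

Compound 4 `O=C(CN1CCCCC1)Nc1ccc(-c2nc3cc(C(F)(F)F)ccc3[nH]2)cc1` differs from compound 3 by piperidin-1-yl in place of diethylamino on a saturated chain carbon bound to a carbonyl carbon. For the measured compounds named here, none of the measured steps touches this part of the molecule: all three alter the substituent on the aromatic carbon, while the amide and its diethylamino end appear in compound 3 alone. Going by the values given here, no measured step therefore bears directly on the change, and nothing points to a direction. The expectation is a number close to that of compound 3, with the step of no change at the digits printed from compound 3 to compound 4 (within the scatter) expected to stay within the scatter. Compound 4 is accordingly estimated at 8000 nM, with a range of 3500 nM to 18000 nM.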

Compound 4, half-maximal cytotoxic concentration: 6000 nM
The estimate for compound 4 lay 1.3-fold (0.12 log units) above the measured number; low and high end bracket the measured number.
By their numbers in this assay, from the lowest: compound 2; then compounds 4 and 3 (each within the scatter of the next); then compound 1.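

In this assay, compound 3 and compound 4 form the only pair shown that differs at the saturated chain carbon bound to a carbonyl carbon, and piperidin-1-yl in place of diethylamino gives a 1.3-fold lower number from compound 3 to compound 4 (0.12 log units; within the scatter). For the compounds shown here, at this position, then, an open diethylamino end and a six-membered non-aromatic ring with one hetero atom cannot be told apart by this read-out, whereas all the earlier steps concerned the group on the aromatic carbon. No measurement at hand offers an explanation for this result.

As far as these compounds go, only these two amine ends are compared, so the effect of a morpholin-4-yl or dimethylamino group at the same carbon remains open. Also open, from the compounds shown here alone, is whether a longer chain between the carbonyl and the amine, or a carboxylic acid in place of the amine, would separate from compound 3 in this test.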